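A few compounds are considered here, and "the series" means these few. Any claim that something is new, unique, unknown or untested is made for them only; others in the source may bear on it.

Working notes on the series, step from compound 2 to compound 4.

Among the measured compounds shown here, compound 2 `O=c1cc(C2CCCCC2)oc2ccc(Cl)cc12` gives 20000 nM in a functional assay on HepG2 cells (Homo sapiens) for cytotoxicity, read by MTT assay (a lower number here means a stronger inhibitor, a higher number a weaker inhibitor), the highest of the three numbers measured so far. For the measured compounds named here, its nearest neighbour is compound 3 `O=c1cc(C2CCCC2)oc2ccc(Cl)cc12`, which gives 13400 nM in this assay; the only measured single-point step is a 1.5-fold lower number from compound 2 to compound 3 (0.17 log units; within the scatter). Going by the values given here, the furthest is compound 1 `COc1cc(-c2cc(=O)c3cc(C(C)C)ccc3o2)cc(OC)c1OC`, which gives 3600 nM in this assay; compound 1 differs from compound 2 in two places at once, so its value shows only that a member of the series with an isopropyl group on the core reaches a lower number.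

Compound 4 `CC(C)c1ccc2oc(C3CCCCC3)cc(=O)c2c1` is not yet measured. It differs from compound 2 in one place: isopropyl in place of chloro on an aromatic carbon. Among the compounds with values here, no measured step exchanges chloro for isopropyl on its own, so no step is a direct guide. Within the data shown here, the one measured step, a 1.5-fold lower number from compound 2 to compound 3 (0.17 log units; within the scatter), concerns the other end of the core and is within the scatter; the value of compound 1 carries a second change as well. Among the measured compounds shown here, the expectation for compound 4 is therefore a number at or somewhat under that of compound 2, with no step expected beyond the scatter: a 1.7-fold lower number from compound 2 to compound 4 (0.22 log units; within the scatter). Compound 4 is estimated at 12000 nM, with a range from 4000 nM to 35000 nM.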

Compound 4, half-maximal inhibitory concentration: 18000 nM
The estimate for compound 4 lay 1.5-fold (0.18 log units) below the measured number; the measured number falls inside the stated range.
By their numbers in this assay, from the lowest: compound 1; then compounds 3, 4 and 2 (each within the scatter of the next).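

In this assay, among the compounds shown here, the exchange of chloro for isopropyl on the aromatic carbon gives a 1.1-fold lower number from compound 2 to compound 4 (0.05 log units; within the scatter) with cyclohexyl held constant, the first single-change reading at this position, and the step gives no sign that this exchange alone separates the two compounds. Compound 4 also shows that isopropyl on the shared core does not by itself go with a number like that of compound 1: both carry isopropyl, yet compound 4 gives 18000 nM and compound 1 gives 3600 nM, so these printed values separate two compounds that differ only in the group carried by compound 1 in place of cyclohexyl. No measured evidence on the compounds bears on the reason for this result.

The compounds shown leave open whether an amine or a carboxylic acid in place of chloro or isopropyl on this aromatic carbon would give a step beyond the scatter. They also leave open whether chloro in place of isopropyl on the core of compound 1 would stay within the scatter of compound 1 , as it does between compound 2 and compound 4.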